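Series notes: benzyl variation on the shared core

This account rests on a few compounds, and the source may have more. Where it says the series, first, only, none or still open, it means among the compounds named here.

Measured so far:
- compound 1, `CNC(=O)c1cc(C(=O)NCCCC2CNCCO2)cn(Cc2ccccc2)c1=O`: 1.4
- compound 2, `CNC(=O)c1cc(C(=O)NC2CC2)cn(Cc2ccc(C)cc2)c1=O`: 3.5

Two compounds of the series have a number in a physicochemical assay for lipophilicity, at pH 7.4; on this read-out higher numbers stand for higher lipophilicity and lower numbers for lower lipophilicity. Compound 1 carries a chain ending in a saturated ring on the side amide, and in this assay compound 1 gives 1.4. Compound 2 carries a cyclopropyl amide and a 4-methylphenyl group on the saturated chain carbon bound to the aromatic nitrogen; in this assay compound 2 gives 3.5, the higher of the two numbers, and the two compounds differ at more than one place, so the gap between them cannot be assigned to a single change.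

Compound 3, `CNC(=O)c1cc(C(=O)NC2CC2)cn(Cc2ccc3nc[nH]c3c2)c1=O`, is not yet measured. It differs from compound 2 at one place: 1H-benzimidazol-6-yl in place of 4-methylphenyl on a saturated chain carbon bound to an aromatic nitrogen. The entering group brings one hydrogen-bond donor and one hydrogen-bond acceptor where the leaving group had none.

Starting from compound 2 with 3.5, a step downward beyond the scatter is expected, a number 1.60 log units lower from compound 2 to compound 3 (beyond the scatter). Compound 3 is estimated at 1.9, with a range from 1.2 to 2.6.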

Compound 3, distribution coefficient: 1.2
For compound 3 the middle estimate is 0.70 log units above the measured one, within the range that was stated.
By their numbers in this assay, from the lowest: compounds 3 and 1 (each within the scatter of the next); then compound 2.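

Among the compounds shown here, compound 2 and compound 3 give the first comparison that differs in one place. With the cyclopropyl amide held constant, 1H-benzimidazol-6-yl in place of 4-methylphenyl on a saturated chain carbon bound to an aromatic nitrogen gives, in this assay, a number 2.30 log units lower from compound 2 to compound 3 (beyond the scatter). This shows that a change at this position alone, with the side amide untouched, is enough to move the read-out by a large step, something the gap between compound 1 and compound 2 could not show, as those two differ at more than one place. No measurement at hand accounts for the step, so it cannot be assigned to any one feature of the entering group, whether its added five-membered ring, its hydrogen-bond donor or its hydrogen-bond acceptor.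

The compounds shown leave open how a single-ring replacement on this carbon, such as pyridyl or a phenyl ring bearing a carboxylic acid or an amine, would compare with 1H-benzimidazol-6-yl. They also leave open whether the step keeps its size when the cyclopropyl amide is replaced by the chain ending in a saturated ring of compound 1.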